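The compounds below may be only part of what the source reports. "The series", "measured", "known", "first", "only" and "open" are said of these compounds alone.

Values measured in a functional assay on MDA-MB-231 cells (Homo sapiens), read by microscopy and transwell migration, with a stated time of 24 h; a lower number here means a stronger inhibitor, a higher number a weaker inhibitor:

- compound 1 `Cc1ccc(-c2cs/c(=N\C(=O)c3ccccc3)n2C)c(C)c1` gives 218 nM
- compound 2 `CCCn1c(-c2ccc(C)cc2C)cs/c1=N\C(=O)c1ccccc1` gives 292 nM
- compound 3 `C=CCn1c(-c2ccc(C)cc2C)cs/c1=N\C(=O)c1ccccc1` gives 456 nM

Two steps fix the place of the allyl member of this set: a 2.1-fold higher number from compound 1 to compound 3 (0.32 log units; beyond the scatter) and a 1.6-fold higher number from compound 2 to compound 3 (0.19 log units; within the scatter). Only the first of these separates the two numbers clearly, so compound 3 is set apart from compound 1 alone.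

The next change keeps the allyl group of compound 3 and leads to compound 4 `C=CCn1c(-c2ccccc2)cs/c1=N\C(=O)c1ccccc1`, with phenyl in place of 2,4-dimethylphenyl on an aromatic carbon. Going by the values given here, no measured step touches this aromatic group. All three alter only the chain on the ring nitrogen, the remaining one being a 1.3-fold higher number from compound 1 to compound 2 (0.13 log units; within the scatter). They show how narrowly this small set spreads, but they do not measure the new change. No step beyond the scatter is therefore expected in this assay, and no direction can be supported, so the range stays wide. Compound 4 is estimated at 450 nM, with an expected range from 170 nM to 1200 nM.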

Compound 4, half-maximal inhibitory concentration: 1200 nM
Compound 4: middle estimate off by 2.7-fold (0.43 log units), on the low side; the measured number falls inside the stated range.
By their numbers in this assay, from the lowest: compounds 1, 2 and 3 (each within the scatter of the next, the first and the last beyond it); then compound 4.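

In this assay, phenyl in place of 2,4-dimethylphenyl on an aromatic carbon gives a 2.6-fold higher number from compound 3 to compound 4 (0.42 log units; beyond the scatter). Going by these compounds alone, the earlier steps changed only the chain on the ring nitrogen, and this is the first evidence that the group on this aromatic carbon also affects the number: with the allyl chain held constant, the version carrying the methyl groups is the stronger inhibitor. Nothing measured here gives a reason for this step.

Compound 4 lacks both methyl groups at once, leaving open whether 2-methylphenyl or 4-methylphenyl would behave like 2,4-dimethylphenyl or like phenyl. From the compounds shown here alone, it is also open whether the same change would have a similar effect with the methyl or propyl chain on the ring nitrogen, or how a methoxy group or a chlorine on the phenyl ring would compare.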